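Swapping Chloro for Fluoro on the Urea Aryl Ring

This account rests on a few compounds, and the source may have more. Where it says the series, first, only, none or still open, it means among the compounds named here.

Compound 1 `COc1ccc(-c2c(Br)c(=O)c3c(OC)cc(OC)cc3n2S(=O)(=O)c2ccc(OC)cc2)cc1` gives 2920 nM in a functional assay on SUP-B15 cells (Homo sapiens) for antiproliferative activity, with a stated time of 72 h; on this read-out higher numbers stand for an effect only at larger amounts of compound and lower numbers for an effect already at smaller amounts. Compound 2 `COC(=O)c1cc(=O)c2cc(NC(=O)Nc3ccc(Cl)c(C(F)(F)F)c3)ccc2[nH]1` reaches only the limit of this assay, > 12600 nM. Compound 3 `COC(=O)c1cc(=O)c2cc(NC(=O)Nc3ccc(Cl)c(Cl)c3)ccc2[nH]1` gives 5520 nM in this assay.

Of the two numbers available, compound 3 and compound 1 lie within the usual scatter of each other, so neither can be called stronger or weaker. Going by the values given here, the only measured step between close neighbours is an at least 2.2-fold lower number from compound 2 to compound 3 (0.35 log units; beyond the scatter), in which a chloro replaces a trifluoromethyl on the aromatic ring of the urea; its size is known only as a bound, since compound 2 sits at the limit (the limit of > 12600 nM in this assay, at which 1 of the 3 values shown sits).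

Compound 4 `COC(=O)c1cc(=O)c2cc(NC(=O)Nc3ccc(F)c(Cl)c3)ccc2[nH]1` differs from compound 3 by fluoro in place of chloro on an aromatic carbon. Among the compounds with values here, the step of an at least 2.2-fold lower number from compound 2 to compound 3 (0.35 log units; beyond the scatter) concerns a different group on the same ring and a larger structural change than a chloro to fluoro swap, so it offers only a rough guide; no measured pair tests this exact exchange. The expectation in this assay is therefore a step within the scatter, with no clear direction. Compound 4 is estimated at 5200 nM, with a range from 2400 nM to 11000 nM. That estimate corresponds to an expected step of a 1.1-fold lower number from compound 3 to compound 4 (0.03 log units; within the scatter).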

Compound 4, half-maximal effective concentration: > 12600 nM
Compound 4: no number, only a limit; the forecaster's own chance of this, stated with the estimate: 15%; middle value at least 2.4-fold (0.38 log units) from the limit.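

The change of a single atom, fluoro in place of chloro on the ring carbon para to a large group, gives an at least 2.2-fold higher number from compound 3 to compound 4 (0.35 log units; beyond the scatter). Going by these compounds alone, this shows that in this assay this position does not treat the two halogens alike, something the earlier compounds could not show, since their only step, an at least 2.2-fold lower number from compound 2 to compound 3 (0.35 log units; beyond the scatter), involved a trifluoromethyl group rather than this exchange. Compound 4, like compound 2, gives only a limit and not a number, so among the three urea compounds only compound 3, with its 3,4-dichlorophenyl group, keeps a measured value, and both steps are known only as bounds: the limit of > 12600 nM in this assay, at which 2 of the 4 values shown sit.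

The compounds shown leave open how far past the limit compound 2 and compound 4 really lie, and so which of the two changes costs more. They also leave open whether a methyl, a nitrile or an amine on this same ring carbon, in place of the chloro of compound 3, would keep a measurable effect or also end at the limit.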